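Swapping a thiazolylamino group for an oxadiazolone: expected solubility

The source may report more compounds than this note shows. Statements on the series, on what has been measured and on what is new or still open speak of the compounds shown alone.

Compound 1 `CC(C)C(Nc1nccs1)c1ccc(-c2ccc3cccc(F)c3c2)[nH]c1=O` gives 32900 nM in a physicochemical assay for solubility, measured as kinetic solubility, at pH 2 (on this read-out lower numbers stand for lower solubility and higher numbers for higher solubility), the second highest of three numbers and within the scatter of both neighbours. Compound 2 `CC(C)[C@H](C[C@H]1CCNC1=O)c1ccc(-c2ccc3cccc(F)c3c2)[nH]c1=O` gives 38300 nM and compound 3 `CC(C)[C@@H](C[C@H]1CCNC1=O)c1ccc(-c2ccc3cccc(F)c3c2)[nH]c1=O` gives 25400 nM; the step of a 1.5-fold lower number from compound 2 to compound 3 (0.18 log units; within the scatter) is small, which fits (the fact that compounds 2 and 3 differ only in the configuration as drawn). Compound 4 `CC(C)C(Cc1noc(=O)[nH]1)c1ccc(-c2ccc3cccc(F)c3c2)[nH]c1=O` differs from compound 1 by a group of 7 heavy atoms (3 carbon, 2 nitrogen, 2 oxygen; one five-membered aromatic ring with 3 hetero atoms) in place of a group of 6 heavy atoms (3 carbon, 2 nitrogen, 1 sulfur; one five-membered aromatic ring with 2 hetero atoms), on a saturated chain carbon bound to an aromatic carbon and a saturated chain carbon. Going by the values given here, none of the measured steps involves this exchange, and the only step measured, a change of configuration, stays within the scatter, so there is no basis for expecting a shift beyond the scatter here. Compound 4 is therefore expected to give about 30000 nM, with a range of 12000 nM to 75000 nM, that is, an expected step of a 1.1-fold lower number from compound 1 to compound 4 (0.04 log units; within the scatter).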

Compound 4, solubility: 18200 nM
Estimate against measurement, compound 4: 1.6-fold (0.22 log units) above; low and high end bracket the measured number.
By their numbers in this assay, from the lowest: compounds 4, 3, 1 and 2 (each within the scatter of the next, the first and the last beyond it).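

In this assay the new ring in place of the (1,3-thiazol-2-yl)amino group gives a 1.8-fold lower number from compound 1 to compound 4 (0.26 log units; within the scatter), so on this saturated chain carbon one five-membered aromatic ring can replace the other without a shift beyond the scatter. Going by these compounds alone, the only step read earlier was a change of configuration, whereas this one changes the group itself. Nothing measured here accounts for the size of this step.

Still open, as far as these compounds go, is whether a carboxylic acid or an amine on the same carbon would also stay within the scatter of compound 1, or whether a longer chain would.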